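The source may report more compounds than this note shows. Statements on the series, on what has been measured and on what is new or still open speak of the compounds shown alone.

Measured in a functional assay on CAKI-1 cells (Homo sapiens) for antiproliferative activity; on this read-out higher numbers stand for weaker inhibition of growth and lower numbers for stronger inhibition of growth:
- compound 1 `Oc1cc(-c2ccc3ccccc3c2)nc2ncccc12`: 5620 nM
- compound 2 `Cc1ccc2c(O)cc(-c3ccc4ccccc4c3)nc2n1`: 5370 nM

Compound 1 holds the highest of these two numbers, though its gap to compound 2 lies within the scatter. Compound 3 `Cc1cnc2nc(-c3ccc4ccccc4c3)cc(O)c2c1` differs from compound 1 by methyl in place of hydrogen on an aromatic carbon, two atoms from the ring nitrogen. Among the compounds with values here, the one measured step that bears on this, a 1.0-fold lower number from compound 1 to compound 2 (0.02 log units; within the scatter), is the same kind of exchange at a different place, and it stays within the scatter. No change beyond the scatter is therefore expected in this assay. The estimated step is a 1.1-fold lower number from compound 1 to compound 3 (0.03 log units; within the scatter). Compound 3 is expected at 5300 nM, with an estimated range of 2700 nM to 10500 nM.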

Compound 3, concentration for 50% growth inhibition: 617 nM
The estimate for compound 3 lay 8.6-fold (0.93 log units) above the measured number; the whole stated range lies above it.
By their numbers in this assay, from the lowest: compound 3; then compounds 2 and 1 (each within the scatter of the next).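

In this assay methyl in place of hydrogen on an aromatic carbon, two atoms from the ring nitrogen, gives a 9.1-fold lower number from compound 1 to compound 3 (0.96 log units; beyond the scatter) while the same exchange at a different place gave a 1.0-fold lower number from compound 1 to compound 2 (0.02 log units; within the scatter) and so, across these compounds, the outcome of adding this methyl depends on where it sits. Nothing available explains why this position responds.

As far as these compounds go, whether an ethyl group, a methoxy group or an amine at this position would give a similar number remains open. So does whether methyl at both places would differ from methyl at this position alone.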